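Trading one bromo for methyl in a cytotoxicity series

The source may report more compounds than this note shows. Statements on the series, on what has been measured and on what is new or still open speak of the compounds shown alone.

In an ADME assay on MT4 cells (Homo sapiens) for inhibition, read by MTT assay, with a stated time of 5 days (on this read-out higher numbers stand for lower toxicity in this test and lower numbers for higher toxicity in this test), compound 1 `Cc1cccc(C)c1Oc1cc(Nc2ccc(C#N)cc2)ncc1[N+](=O)[O-]` gives 126000 nM, and compound 2 `N#Cc1ccc(Nc2cc(Oc3c(Br)cc(Br)cc3Br)c([N+](=O)[O-])cn2)cc1` gives 7490 nM, the lower of the two numbers. Compound 3 `Cc1cc(Br)c(Oc2cc(Nc3ccc(C#N)cc3)ncc2[N+](=O)[O-])c(Br)c1` carries methyl in place of bromo on an aromatic carbon, which turns 2,4,6-tribromophenyl into 2,6-dibromo-4-methylphenyl. Among the compounds with values here, the only measured step bearing on this is the large 17-fold lower number from compound 1 to compound 2 (1.23 log units; beyond the scatter), from 2,6-dimethylphenyl to 2,4,6-tribromophenyl. The new change reverses part of that swap, so a smaller step towards higher numbers in this assay is expected: a 2.7-fold higher number from compound 2 to compound 3 (0.43 log units; beyond the scatter). For compound 3 the estimated value is 20000 nM, with an expected range of 8000 nM to 60000 nM.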

Compound 3, half-maximal cytotoxic concentration: 23600 nM
For compound 3 the middle estimate is 1.2-fold (0.07 log units) below the measured one; the measured number falls inside the stated range.
By their numbers in this assay, from the lowest: compound 2; then compound 3; then compound 1.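

Swapping only this bromo for methyl, while the two other bromo groups stay, gives a 3.2-fold higher number from compound 2 to compound 3 (0.50 log units; beyond the scatter) in this assay and so shows that this single place alone moves the read-out. There is still a 5.3-fold lower number from compound 1 to compound 3 (0.73 log units; beyond the scatter) and so this swap closes only part of the gap to compound 1. Nothing available explains either step.

As far as these compounds go, how a methoxy group or an amine at this same place would read remains open. So does whether a chloro group there would sit closer to bromo or to methyl.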